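From Compound 2 to Its Bromo Analogue, Compound 3

The source may report more compounds than this note shows. Statements on the series, on what has been measured and on what is new or still open speak of the compounds shown alone.

Compound 1 `O=C(/C=C/c1ccc(C(F)(F)F)cc1)Nc1nnc(-c2ccccc2)s1` gives 1.78 ug/mL
Compound 2 `COc1ccc(/C=C/C(=O)Nc2nnc(-c3ccccc3)s2)cc1` gives 0.76 ug/mL

These two numbers come from a functional assay on A549 cells (Homo sapiens) for antiproliferative activity, read by MTT assay, with a stated time of 48 h (a lower number here means a stronger inhibitor, a higher number a weaker inhibitor), where compound 2 holds the lower of the two. Compound 3 `COc1ccc(/C=C/C(=O)Nc2nnc(-c3ccc(Br)cc3)s2)cc1` has not yet been measured. It differs from compound 2 by bromo in place of hydrogen on an aromatic carbon, which reads as phenyl to 4-bromophenyl. Within the data shown here, the only measured step is a 2.3-fold lower number from compound 1 to compound 2 (0.37 log units; beyond the scatter), a modest change of methoxy in place of trifluoromethyl. It lies elsewhere in the molecule, so it bears on the new change only loosely and says nothing about the effect of bromo. With no measured guide to direction, no step beyond the scatter is expected. The expected step is a 1.1-fold lower number from compound 2 to compound 3 (0.04 log units; within the scatter) as estimated here. For compound 3 the estimated value is 0.7 ug/mL, with an expected range from 0.25 ug/mL to 1.8 ug/mL as the likely span.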

Compound 3, half-maximal inhibitory concentration: 1.04 ug/mL
The estimate for compound 3 lay 1.5-fold (0.17 log units) below the measured number; low and high end bracket the measured number.
By their numbers in this assay, from the lowest: compounds 2, 3 and 1 (each within the scatter of the next, the first and the last beyond it).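

In this assay, among these compounds, the change from phenyl to 4-bromophenyl gives a 1.4-fold higher number from compound 2 to compound 3 (0.14 log units; within the scatter), the first reading at this place in the molecule, since the earlier step, methoxy in place of trifluoromethyl, lay elsewhere. Bromo, a single heavy atom on an aromatic carbon, para to a large group, therefore leaves the number within the scatter in this pair, so this position accepts that one group without a measurable penalty. No available evidence accounts for this result.

A single substituent at one place cannot define a trend, so the compounds shown leave open how an amine or a carboxylic acid would read there. They also leave open whether the same bromo change would give a similar step on compound 1, which carries trifluoromethyl in place of methoxy.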